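This account rests on a few compounds, and the source may have more. Where it says the series, first, only, none or still open, it means among the compounds named here.

Of the compounds shown here, three of a shared core have been tested in a functional assay on RXF 393 cells (Homo sapiens) for cytotoxicity, read by sulforhodamine B assay, with a stated time of 48 h, tested at 0.1 uM; on this read-out higher numbers stand for a weaker effect at the one concentration tested and lower numbers for a stronger effect. Compound 1 `COc1cc(-c2cc(/C=C/C(=O)c3ccc(N)cc3)[nH]n2)cc(OC)c1OC` gives 91% in this assay. Compound 2 `COc1ccc(C(=O)/C=C/c2cc(-c3cc(OC)c(OC)c(OC)c3)n[nH]2)cc1OC` gives 100%, and compound 3 `COc1ccc(C(=O)/C=C/c2cc(-c3cc(OC)c(OC)c(OC)c3)n[nH]2)cc1` gives 90%. Each pair among them differs in one place only. From compound 1 to compound 2 the change is 4-aminophenyl in place of 3,4-dimethoxyphenyl on a carbonyl carbon read in reverse, and the step is a number 9 percentage points higher from compound 1 to compound 2 (within the scatter). From compound 2 to compound 3 the change is hydrogen in place of methoxy on an aromatic carbon, with a step of a number 10 percentage points lower from compound 2 to compound 3 (within the scatter). From compound 1 to compound 3 the step is a number 1 percentage points lower from compound 1 to compound 3 (within the scatter). All three steps sit within the scatter, so none of these compounds can be said to act differently from another at the one concentration tested.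

Compound 4 `COc1ccc(-c2cc(/C=C/C(=O)c3ccc(N)cc3)[nH]n2)cc1OC` has not yet been measured. It differs from compound 1 by hydrogen in place of methoxy on an aromatic carbon. Going by the values given here, this is the same kind of change as the one from compound 2 to compound 3, but not the same: in compound 4 the place is also meta to a methoxy group, which is not so in compound 3. The cores of compound 1 and compound 2 differ as told by 4-aminophenyl in place of 3,4-dimethoxyphenyl on a carbonyl carbon.

Because the measured step of a number 10 percentage points lower from compound 2 to compound 3 (within the scatter) stayed within the scatter, a step of about a number 6 percentage points lower from compound 1 to compound 4 (within the scatter) is expected from compound 1 to compound 4. The estimate for compound 4 in this assay is 85%, expected between 70% and 100%.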

Compound 4, a percentage reported as activity, at one concentration (the size of the read-out at that concentration, not a potency): 92%
For compound 4 the middle estimate is 7 percentage points below the measured one, within the range that was stated.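

In this assay, putting hydrogen in place of methoxy on the core of compound 1 gives a number 1 percentage points higher from compound 1 to compound 4 (within the scatter), so this single change leaves no effect that can be told apart from ordinary variation between repeats. Set beside the same change on the other core, the two steps do not differ: the same change on two cores in this assay, a number 10 percentage points lower (within the scatter) from compound 2 to compound 3 and a number 1 percentage points higher (within the scatter) from compound 1 to compound 4, 11 percentage points apart, within the scatter of two such steps. This shows that, on these two cores and at the one concentration tested, the change gave no step beyond the scatter on either core, but it does not show that a real effect carries over from one core to the other, since steps this small cannot show whether the two cores respond alike or differently.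

The compounds shown leave open what other groups would do at the place where the methoxy was lost, such as a hydroxyl, an ethoxy or a longer ether chain, a fluorine or a chlorine. They also leave open whether a carboxylic acid or an amide in place of the amino group on the aromatic ring attached to the carbonyl would give a read-out beyond the scatter from compound 1 in this assay, and whether testing at other concentrations would separate these compounds at all.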